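Lengthening the Chain Beyond Compound 3

A few compounds are considered here, and "the series" means these few. Any claim that something is new, unique, unknown or untested is made for them only; others in the source may bear on it.

In a functional assay on A549 cells (Homo sapiens) for inhibition, read by colorimetric assay and MTT assay, with a stated time of 72 h (a higher number here means a weaker inhibitor, a lower number a stronger inhibitor), compound 1 (`C=CCCCCOc1ccccc1-c1cnc(OCCC=C)n1C`) gives 9000 nM, compound 2 (`C=CCCCCOc1ccccc1-c1cnc(OCCCC=C)n1C`) gives 3000 nM and compound 3 (`C=CCCCCOc1ccccc1-c1cnc(OCCCCC=C)n1C`) gives 7000 nM. Compound 3 therefore stands level with compound 1, at a 1.3-fold lower number from compound 1 to compound 3 (0.11 log units; within the scatter), and apart from compound 2, at a 2.3-fold higher number from compound 2 to compound 3 (0.37 log units; beyond the scatter). Compound 4 (`C=CCCCCCOc1ncc(-c2ccccc2OCCCCC=C)n1C`) differs from compound 3 by allyl in place of vinyl on a saturated chain carbon, four bonds along the chain from an oxygen on an aromatic ring, with allyl in place of vinyl four bonds along the chain from an oxygen on an aromatic ring. The same exchange two bonds along gave a 3.0-fold lower number from compound 1 to compound 2 (0.48 log units; beyond the scatter), and three bonds along gave a 2.3-fold higher number from compound 2 to compound 3 (0.37 log units; beyond the scatter). These modest steps run in opposite directions, so no step beyond the scatter is expected in this assay. The expected step is a 1.1-fold higher number from compound 3 to compound 4 (0.06 log units; within the scatter). For compound 4 the estimate is 8000 nM, with an expected range from 3500 nM to 20000 nM.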

Compound 4, half-maximal inhibitory concentration: 62000 nM
Compound 4: the middle estimate sits 7.8-fold (0.89 log units) below what was measured; measured number above the stated range.
By their numbers in this assay, from the lowest: compound 2; then compounds 3 and 1 (each within the scatter of the next); then compound 4.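

At this position the added carbon costs more than any earlier exchange in this assay (with an 8.9-fold higher number from compound 3 to compound 4 (0.95 log units; beyond the scatter)) and (with a 21-fold higher number from compound 2 to compound 4 (1.32 log units; beyond the scatter)) and (with a 6.9-fold higher number from compound 1 to compound 4 (0.84 log units; beyond the scatter)), which sets compound 4 beyond the scatter from all three others. The exchange of vinyl for allyl therefore does not carry over from one chain position to the next: the same change on two cores in this assay, a 3.0-fold lower number (0.48 log units; beyond the scatter) from compound 1 to compound 2 and an 8.9-fold higher number (0.95 log units; beyond the scatter) from compound 3 to compound 4, 27-fold (1.42 log units) apart, beyond the scatter of two such steps. The larger extension diverges in the same way: the same change on two cores in this assay, a 1.3-fold lower number (0.11 log units; within the scatter) from compound 1 to compound 3 and a 21-fold higher number (1.32 log units; beyond the scatter) from compound 2 to compound 4, 27-fold (1.42 log units) apart, beyond the scatter of two such steps.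

The compounds shown leave open whether a longer chain would raise the number further. They also leave open how a saturated chain, or an amine or carboxylic acid at the chain end, would read here.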